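The source may report more compounds than this note shows. Statements on the series, on what has been measured and on what is new or still open speak of the compounds shown alone.

In an ADME assay on Vero cells (Chlorocebus sabaeus) for cytotoxicity, read by MTT assay, with a stated time of 72 h (a higher number here means that more compound is tolerated, a lower number that less compound is tolerated), three compounds sharing one core have been measured. Compound 1 `COc1ccc(/C=C(\C)C(=O)/C=C/c2cccc(Br)c2)cc1` gives 153000 nM, compound 2 `COc1ccc(/C=C(\C)C(=O)/C=C/c2ccccc2Cl)cc1` gives 74300 nM, and compound 3 `COc1ccc(/C=C(\C)C(=O)/C=C/c2ccccc2Br)cc1` gives 71000 nM. Compound 3 thus sits level with compound 2, and the two stand apart from compound 1. The next compound, compound 4 `COc1ccc(/C=C(\C)C(=O)/C=C/c2ccccc2F)cc1`, differs from compound 3 in one place: fluoro in place of bromo on an aromatic carbon, with fluoro in place of bromo on an aromatic carbon, ortho to a large group. The closest evidence is bromo in place of chloro, which gave a 1.0-fold lower number from compound 2 to compound 3 (0.02 log units; within the scatter), a step within the scatter. The modest steps came with 2-bromophenyl in place of 3-bromophenyl, a 2.2-fold lower number from compound 1 to compound 3 (0.33 log units; beyond the scatter), and with 2-chlorophenyl in place of 3-bromophenyl, a 2.1-fold lower number from compound 1 to compound 2 (0.31 log units; beyond the scatter). Within the data shown here, compound 4 keeps its halogen where compound 2 and compound 3 have theirs, although no fluoro compound has yet been measured. The expected change is therefore small, with a 1.1-fold higher number from compound 3 to compound 4 (0.05 log units; within the scatter) estimated to stay within the scatter. For compound 4 the estimate is 80000 nM, with an expected range of 45000 nM to 145000 nM.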

Compound 4, half-maximal cytotoxic concentration: 81200 nM
Beside the measured number, compound 4's estimate is 1.0-fold (0.01 log units) below it, and the stated range covers the measured number.
By their numbers in this assay, from the lowest: compounds 3, 2, 4 and 1 (each within the scatter of the next, the first and the last beyond it).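

In this assay fluoro on this aromatic carbon, ortho to a large group, reads the same as bromo (a 1.1-fold higher number from compound 3 to compound 4 (0.06 log units; within the scatter)) and chloro (a 1.1-fold higher number from compound 2 to compound 4 (0.04 log units; within the scatter)), so the exchange among these three halogens has shown no effect beyond the scatter at this position. The separation from compound 1 seen with the 2-chlorophenyl and 2-bromophenyl groups is not repeated with 2-fluorophenyl, since that step lies within the scatter (a 1.9-fold lower number from compound 1 to compound 4 (0.28 log units; within the scatter)). Nothing measured here explains why these halogens read alike.

From the compounds shown here alone, whether an amine or a carboxylic acid on the same aromatic carbon would read like the halogens remains open. Also open, going by these compounds, is whether fluoro or chloro in place of the bromo of the 3-bromophenyl group would leave the number of compound 1 unchanged.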